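The source may report more compounds than this note shows. Statements on the series, on what has been measured and on what is new or still open speak of the compounds shown alone.

Compound 1 `Cc1nnc(SCC(=O)c2ccccc2)n1N1C(=O)c2ccccc2C1=O` in a functional assay on A549 cells (Homo sapiens) for cytotoxicity, read by MTT assay, with a stated time of 48 h (a higher number here means a weaker inhibitor, a lower number a stronger inhibitor), gives > 200000 nM, which is a limit of the assay and not a number.
Compound 2 `C=CCSc1nnc(CC)n1N1C(=O)c2ccccc2C1=O` in this assay gives > 200000 nM, again a limit.
Compound 3 `C=CCSc1nnc(CCC)n1N1C(=O)c2ccccc2C1=O` in this assay gives > 200000 nM, also a limit.

Compound 3 thus sits at the limit of > 200000 nM in this assay, at which 3 of the 3 values shown sit, and no number for it is known. Compound 4 `CCCc1nnc(SC)n1N1C(=O)c2ccccc2C1=O` differs from it in one place: hydrogen in place of vinyl on a saturated chain carbon bound to a sulfur. For the measured compounds named here, the only single-change step measured is a step that the two limits leave unreadable from compound 2 to compound 3, which runs between two limits and touches the propyl side, not the allylsulfanyl group, so nothing readable bears on the change. The expected step is a step that the limit leaves unreadable from compound 3 to compound 4, none beyond the scatter. Compound 4 is therefore expected at 300000 nM in this assay, between 100000 nM and 1000000 nM, most likely reported again only as a limit.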

Compound 4, half-maximal inhibitory concentration: > 200000 nM
Compound 4: a limit, no number; the forecaster's own chance of this, stated with the estimate: 85%; the middle value does not contradict the limit.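

No step can be read between compound 3 and compound 4, since both values are limits of the assay and not numbers: the limit of > 200000 nM in this assay, at which 4 of the 4 values shown sit.

The compounds shown leave open whether any change on the shared core gives a readable number in this assay.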